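The source may hold more compounds than are shown below. What is called first, only, known or untested is meant among the compounds shown, and "the series" means these compounds.

Measured so far in an ADME assay on microsomes from liver (Homo sapiens) for metabolic stability; on this read-out higher numbers stand for a longer-lived compound and lower numbers for a shorter-lived compound:
- compound 1, `COc1ccc(OC)c(-c2cc(C3=Nc4c(C(C)(C)C)nn(CCCO)c4C(=O)NC3)ccc2OC)c1`: 1.02 h
- compound 2, `COc1ccc(C2=Nc3c(C(C)(C)C)nn(CCCO)c3C(=O)NC2)cc1-c1ccc(F)cc1F`: 2 h

Among the measured compounds shown here, compound 2 and compound 1 are the only two measured members, and the single step between them, a 2.0-fold higher number from compound 1 to compound 2 (0.29 log units; within the scatter), lies within the scatter, so compound 2 cannot be set apart from compound 1 on this assay. That step swaps the whole aryl group, 2,4-difluorophenyl in place of 2,5-dimethoxyphenyl, and even that wholesale exchange left the number where it was.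

Compound 3, `COc1ccc(C2=Nc3c(C(C)(C)C)nn(CCCO)c3C(=O)NC2)cc1-c1ccccc1F`, is the next member. Against compound 2 the change is hydrogen in place of fluoro on an aromatic carbon. For the measured compounds named here, no measured step touches this change directly. Going by the values given here, the one step that exists, a 2.0-fold higher number from compound 1 to compound 2 (0.29 log units; within the scatter), exchanges the entire ring rather than a single fluoro, and it stayed within the scatter. Nothing in the data supports a move in either direction for compound 3. The expected step is a 1.2-fold lower number from compound 2 to compound 3 (0.07 log units; within the scatter), which stays within the scatter. Compound 3 is therefore estimated at 1.7 h in this assay, with a range from 0.7 h to 3.5 h.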

Compound 3, half-life: 0.8 h
Estimate against measurement, compound 3: 2.1-fold (0.33 log units) above, within the range that was stated.
By their numbers in this assay, from the lowest: compounds 3, 1 and 2 (each within the scatter of the next, the first and the last beyond it).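

In this assay, among the compounds shown here, the fluoro on the carbon para to a large group gives the first step that lies beyond the scatter: the change to hydrogen gives a 2.5-fold lower number from compound 2 to compound 3 (0.40 log units; beyond the scatter) and so counts as a modest move, whereas the exchange of the whole aryl group between compound 1 and compound 2 did not leave the scatter. For the compounds shown here, the 2-fluorophenyl and 2,5-dimethoxyphenyl groups, by contrast, cannot be told apart on this read-out, with a 1.3-fold lower number from compound 1 to compound 3 (0.11 log units; within the scatter) and compound 1 lying within the scatter of both compound 2 and compound 3, so the only separation among the three rests on the single pair compound 2 and compound 3. No supporting data bear on why this one fluoro registers on the half-life.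

From the compounds shown here alone, whether the separation is peculiar to fluoro stays open, and a chloro, methyl or nitrile on that same aromatic carbon would test it. Also open, going by these compounds, is what the remaining fluoro contributes, which a plain phenyl group in place of the 2-fluorophenyl of compound 3 would address.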